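The source may hold more compounds than are shown below. What is called first, only, known or untested is meant among the compounds shown, and "the series" means these compounds.

Compound 2 `COc1ccc(C(=O)O[C@@H]2CO[C@H]3[C@@H]2OC[C@@H]3OC(=O)c2ccccc2OC(C)=O)cc1` is one of two close relatives that have been run through an ADME assay on a cell-free system (plasma, Homo sapiens) for metabolic stability, with Plasma (Rattus norvegicus) as the target, read by HPLC, at pH 7.4; a higher number here means that the compound lasts longer, a lower number that the compound disappears faster. In this assay compound 2 gives 0.0525 h. For the measured compounds named here, its only neighbour is compound 1 `COc1cccc(C(=O)O[C@@H]2CO[C@H]3[C@@H]2OC[C@@H]3OC(=O)c2ccccc2OC(C)=O)c1`, which carries a 3-methoxyphenyl where compound 2 carries a 4-methoxyphenyl; in this assay compound 1 gives 0.0525 h. The step of no change at the digits printed from compound 1 to compound 2 (within the scatter) shows that moving from 3-methoxyphenyl to 4-methoxyphenyl on the carbonyl carbon left the half-life where it was, so compound 2 stands level with compound 1.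

Compound 3 `CC(=O)Oc1ccccc1C(=O)O[C@H]1CO[C@H]2[C@@H]1OC[C@H]2OC(=O)c1ccc(-c2ccccc2)cc1` has not yet been measured in this assay. Set against compound 2, the change is phenyl in place of methoxy on an aromatic carbon; cut one bond further out it reads 4-methoxyphenyl to 4-phenylphenyl. Going by the values given here, only that one flat step bears on this change, and it concerned the methoxy alone; nothing measured speaks to replacing the methoxy with a whole phenyl. On that thin evidence the most reasonable expectation is a small step, a 1.1-fold lower number from compound 2 to compound 3 (0.02 log units; within the scatter), held within the scatter but with a wider range to allow for the larger change. Compound 3 is therefore estimated at 0.05 h, between 0.02 h and 0.13 h.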

Compound 3, half-life: > 0.333 h
Compound 3 ended at the assay's limit; the forecaster's own chance of this, stated with the estimate: 5%; middle value at least 6.6-fold (0.82 log units) from the limit.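

Moving the methoxy between ring positions had shown nothing, so the flat step from the earlier compounds gave no sign that this part of the molecule matters for how long a compound lasts. Phenyl in place of methoxy on this aromatic carbon, para to a large group, does matter, giving an at least 6.3-fold higher number from compound 2 to compound 3 (0.80 log units; beyond the scatter). Set against the 3-methoxyphenyl relative, the change to 4-phenylphenyl gives an at least 6.3-fold higher number from compound 1 to compound 3 (0.80 log units; beyond the scatter), so the swap stands clear of the scatter from both methoxy compounds.

In this assay compound 3 gives > 0.333 h, which is a limit of the assay and not a number, so both steps mark only a lower bound on the size of the change: the limit of > 0.333 h in this assay, at which 1 of the 3 values shown sits.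

For the compounds shown here, with only one compound carrying a phenyl here, it stays open whether the longer half-life comes with the added aromatic ring or simply with the loss of the methoxy, and whether an amine, a carboxylic acid or a longer alkyl chain at this place would act the same way. The compounds shown also leave open how far past that limit compound 3 really lies.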